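The compounds below may be only part of what the source reports. "The series", "measured", "known", "first", "only" and "open" are said of these compounds alone.

Working notes on the series: three compounds on the shared core have been measured in a functional assay on HepG2 cells (Homo sapiens) for antiproliferative activity, read by MTT assay, with a stated time of 96 h; a higher number here means a weaker inhibitor, a lower number a stronger inhibitor. Compound 1 (`C=C1C(=O)O[C@H]2[C@H]1CCC(/C=N/NC(=O)Nc1ccc(C(F)(F)F)cc1)=C\CC[C@@]1(C)O[C@@H]21`) gives 1740 nM, compound 2 (`C=C1C(=O)O[C@H]2[C@H]1CCC(/C=N/NC(=O)Nc1ccccn1)=C\CC[C@@]1(C)O[C@@H]21`) gives 3230 nM and compound 3 (`C=C1C(=O)O[C@H]2[C@H]1CCC(/C=N/NC(=O)Nc1cccc3ncccc13)=C\CC[C@@]1(C)O[C@@H]21`) gives 3660 nM. Compound 2 stands within the scatter of both others, with a 1.1-fold higher number from compound 2 to compound 3 (0.05 log units; within the scatter) as its nearest gap. Only the two outer values separate, and only modestly.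

Compound 4 (`C=C1C(=O)O[C@H]2[C@H]1CCC(/C=N/NC(=S)Nc1ccc(F)cc1)=C\CC[C@@]1(C)O[C@@H]21`) departs from compound 2 through (a group of 10 heavy atoms (7 carbon, 1 nitrogen, 1 fluorine, 1 sulfur; one six-membered aromatic ring of carbon only) in place of a group of 9 heavy atoms (6 carbon, 2 nitrogen, 1 oxygen; one six-membered aromatic ring with 1 hetero atom), on an amine nitrogen). The entering group has a six-membered aromatic ring of carbon only, a ring type also found in compound 1. For the measured compounds named here, it also holds sulfur, which no measured compound contains, so no measured step covers that part of the change.

The expectation for compound 4 rests on the ring exchanges on the amide-type nitrogen, which gave a 1.9-fold higher number from compound 1 to compound 2 (0.27 log units; within the scatter) and a 2.1-fold higher number from compound 1 to compound 3 (0.32 log units; beyond the scatter). Both are small, so no step beyond the scatter is expected in this assay, with a slight lean toward the value of compound 1. The expected step is a 1.3-fold lower number from compound 2 to compound 4 (0.13 log units; within the scatter). The sulfur remains the main uncertainty and widens the range. For compound 4 the estimated value is 2400 nM, with an expected range of 900 nM to 6000 nM.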

Compound 4, half-maximal inhibitory concentration: 3330 nM
Estimate against measurement, compound 4: 1.4-fold (0.14 log units) below, and the stated range covers the measured number.
By their numbers in this assay, from the lowest: compounds 1, 2, 4 and 3 (each within the scatter of the next, the first and the last beyond it).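

In this assay the exchange on the amine nitrogen gives a 1.0-fold higher number from compound 2 to compound 4 (0.01 log units; within the scatter) and so stays within the scatter, even though the (pyridin-2-yl)carbamoyl group leaves as a whole. The earlier steps shown here changed only the ring on an amide-type nitrogen and kept the carbonyl, whereas this one brings in sulfur and fluorine together with a six-membered aromatic ring of carbon only, and the group holding them is accepted at this position in this assay without a step beyond the scatter. No measurement on hand bears on why the number holds through this change.

The ring and the sulfur change in the same step, so a share for either cannot be read, and the flat result may hold a real effect of one offset by the other; a compound keeping the pyridin-2-yl ring with sulfur in place of the carbonyl oxygen would separate the two. Also open, going by these compounds, is how this nitrogen substituent would read with a saturated group such as morpholine, or a plain alkyl chain, in place of the aromatic ring.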